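Taking the nitro group off compound 2

The source may hold more compounds than are shown below. What is called first, only, known or untested is meant among the compounds shown, and "the series" means these compounds.

Among the compounds with values here, in an ADME assay on MT4 cells (Homo sapiens) for cytotoxicity (a lower number here means that less compound is tolerated, a higher number that more compound is tolerated), compound 2 `O=[N+]([O-])c1ccc(NC(=S)Nc2cccc(C(F)(F)F)c2)cc1` gives 9200 nM, the lower of the two numbers so far, while compound 1 `CC[C@H]1CC[C@H](c2ccc(NC(=S)Nc3cccc(C(F)(F)F)c3)cc2)CC1` gives 39000 nM. Within the data shown here, the one measured step is a 4.2-fold lower number from compound 1 to compound 2 (0.63 log units; beyond the scatter), with nitro in place of 4-ethylcyclohexyl on an aromatic carbon. Compound 3 `FC(F)(F)c1cccc(NC(=S)Nc2ccccc2)c1` now puts hydrogen in place of nitro on that same carbon, para to a large group: hydrogen in place of nitro on an aromatic carbon. Among the measured compounds shown here, no compound with hydrogen there has been measured, so this single step is the only guide. The lower number came with nitro in compound 2, at 9200 nM, so removing nitro is expected to move the number up, probably by less than the earlier step. The expected change in this assay is a 2.2-fold higher number from compound 2 to compound 3 (0.34 log units; beyond the scatter), a small one. For compound 3 the estimated value is 20000 nM, with an expected range from 8000 nM to 50000 nM.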

Compound 3, half-maximal cytotoxic concentration: 39000 nM
Estimate against measurement, compound 3: 2.0-fold (0.29 log units) below, within the range that was stated.
By their numbers in this assay, from the lowest: compound 2; then compounds 1 and 3 (each within the scatter of the next).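

Removing the nitro group in this assay gives a 4.2-fold higher number from compound 2 to compound 3 (0.63 log units; beyond the scatter), so the lower number of compound 2 is now seen from two sides: both the 4-ethylcyclohexyl group and plain hydrogen on this aromatic carbon leave the number well clear of it. Those two replacements cannot be told apart, with no change at the digits printed from compound 1 to compound 3 (within the scatter), even though one is a bulky group carrying its own ring and the other adds no heavy atom at all. Among these three compounds, then, size at this place makes no visible difference here, and nitro alone stands apart.

On these data alone, whether an amine, a carboxylic acid or a methoxy group on this carbon would match nitro or hydrogen remains open. Nothing available explains why nitro stands apart from the other two.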